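This account rests on a few compounds, and the source may have more. Where it says the series, first, only, none or still open, it means among the compounds named here.

Of the compounds shown here, two sharing one core have been measured so far in a functional assay on MCF7 cells (Homo sapiens) for antiproliferative activity, read by MTT assay, with a stated time of 48 h; on this read-out lower numbers stand for stronger inhibition and higher numbers for weaker inhibition. Compound 1 (`CC(=O)N1N=C(c2ccc3ccccc3c2)OC1c1ccc(F)cc1`), which carries 4-fluorophenyl on a saturated ring carbon, gives 3.02 ug/mL. Compound 2 (`CC(=O)N1N=C(c2ccc3ccccc3c2)OC1c1ccccn1`), which has pyridin-2-yl at that place, gives 6.02 ug/mL. For the measured compounds named here, the only measured step is a 2.0-fold higher number from compound 1 to compound 2 (0.30 log units; within the scatter), so compound 2 stands within the scatter of its single neighbour. Compound 3 (`CC(=O)N1N=C(c2ccc3ccccc3c2)OC1c1ccc(C)cc1`) keeps the core and has 4-methylphenyl in place of pyridin-2-yl on a saturated ring carbon. Going by the values given here, the one step that bears on this change is the exchange between 4-fluorophenyl and pyridin-2-yl at the same carbon, a 2.0-fold higher number from compound 1 to compound 2 (0.30 log units; within the scatter), and it stayed within the scatter. Among the compounds with values here, no methyl-bearing compound has been measured, so the data offer no direct guide to that group. No step beyond the scatter is therefore expected in this assay, only a slight lean toward the number of compound 1. The expected step is a 1.5-fold lower number from compound 2 to compound 3 (0.18 log units; within the scatter). Compound 3 is estimated at 4 ug/mL, with an expected range from 1.8 ug/mL to 9 ug/mL.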

Compound 3, half-maximal inhibitory concentration: 2.9 ug/mL
For compound 3 the middle estimate is 1.4-fold (0.14 log units) above the measured one; measured number inside the range.
By their numbers in this assay, from the lowest: compounds 3, 1 and 2 (each within the scatter of the next, the first and the last beyond it).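

In this assay, for the compounds shown here, pyridin-2-yl giving way to 4-methylphenyl on the saturated ring carbon produces the first step at this position to lie beyond the scatter, a 2.1-fold lower number from compound 2 to compound 3 (0.32 log units; beyond the scatter), although it is only a modest one. The two carbon-only rings cannot be told apart: methyl in place of fluoro on an aromatic carbon gives a 1.0-fold lower number from compound 1 to compound 3 (0.02 log units; within the scatter), so compound 1 and compound 3 form a level pair, while compound 2 is separated from compound 3 but remains within the scatter of compound 1. Nothing in the data accounts for this small separation, which stands as an observation only.

The compounds shown explore only six-membered aromatic rings at this carbon and so leave open how it would respond to a methoxy group or an amine on the phenyl ring, or to an open alkyl chain in place of the ring. They also leave open whether the acetyl group on the neighbouring ring atom could be replaced by a longer acyl chain without changing the numbers in this assay.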